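A few compounds are considered here, and "the series" means these few. Any claim that something is new, unique, unknown or untested is made for them only; others in the source may bear on it.

The compounds in this series share one core and vary in their amino substituents. In an ADME assay on J774.A1 cells (Mus musculus) for inhibition, read by MTT assay, with a stated time of 72 h (on this read-out lower numbers stand for an effect already at smaller amounts and higher numbers for an effect only at larger amounts of compound), compound 1 (`CNc1nc(NCc2ccco2)nc2ccccc12`) stands as "not determined" (no result reported) and so offers no number. Within the data shown here, compound 2 (`CNc1nc(NC2CCCC2)nc2ccccc12`) gives 39000 nM in this assay and is the only one of the measured compounds with a figure. Compound 3 (`CNc1nc(NC(C)C)nc2ccccc12`) stands as "not determined" (no result reported) in this assay and therefore gives no single number from which to take a step. Compound 4 (`CNc1nc(NC)c2ccccc2n1`) follows from compound 3 through methyl in place of isopropyl on a nitrogen on an aromatic ring and so has methyl in place of isopropyl on a nitrogen on an aromatic ring. Among the measured compounds shown here, no measured step shows what this change does, so only a modest step is expected in this assay, upward if anything. The expected number for compound 4 should lie close to that of compound 2 at 39000 nM or somewhat larger. For compound 4 the estimated value is 50000 nM, with an expected range from 20000 nM to 100000 nM on this reasoning.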

Compound 4, half-maximal effective concentration: > 133000 nM
Compound 4 gave a limit, no number; the forecaster's own chance of this, stated with the estimate: 35%; at least 2.6-fold (0.42 log units) between middle value and limit.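

In this assay compound 4 gives > 133000 nM, which is a limit of the assay and not a number: the limit of > 133000 nM in this assay, at which 1 of the 4 values shown sits.

Among these compounds, this is the first sign that the group on this nitrogen on an aromatic ring matters in this assay: with methyl in place of cyclopentyl, the data show an at least 3.4-fold higher number from compound 2 to compound 4 (0.53 log units; beyond the scatter). The steps involving compound 1 and compound 3 cannot be read, so isopropyl gives no intermediate point between these two groups.

On these data alone, how far the number for compound 4 lies past its limit remains open, as does the shape of the change between methyl and cyclopentyl. As far as these compounds go, it is also open whether a longer chain, a benzyl group or a chain ending in a carboxylic acid on this nitrogen would bring the number nearer to that of compound 2.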